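Swapping Methoxy for Amino in Compound 1

This account rests on a few compounds, and the source may have more. Where it says the series, first, only, none or still open, it means among the compounds named here.

Compound 1 `COc1ccc(S(=O)(=O)Nc2cccc3cc[nH]c23)cc1` in a functional assay on P388 cells (Mus musculus) for antiproliferative activity, read by colorimetric assay and MTT assay (on this read-out higher numbers stand for weaker inhibition and lower numbers for stronger inhibition), gives 1.1 ug/mL. Compound 2 `COc1ccc(S(=O)(=O)Nc2ccc(Cl)c3cc[nH]c23)cc1` gives 1.1 ug/mL, and no change at the digits printed from compound 1 to compound 2 (within the scatter). Compound 3 `COc1ccc(S(=O)(=O)Nc2cccc3cc(O)[nH]c23)cc1` gives 0.11 ug/mL, so a 10-fold lower number from compound 1 to compound 3 (1.00 log units; beyond the scatter). Compound 1 therefore sits level with compound 2 at the high end of the three numbers, with compound 3 the furthest away.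

Compound 4 `Nc1ccc(S(=O)(=O)Nc2cccc3cc[nH]c23)cc1` differs from compound 1 as follows: amino in place of methoxy on an aromatic carbon. Neither measured step touches this part of the molecule; both change the other ring of the shared core. Among the measured compounds shown here, no measured step bears on this change, so no direction can be drawn from the data. The expectation is a step within the scatter, no change at the digits printed from compound 1 to compound 4 (within the scatter). Compound 4 is estimated at 1.1 ug/mL, within 0.3 ug/mL to 4 ug/mL.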

Compound 4, half-maximal inhibitory concentration: 14 ug/mL
Compound 4: the middle estimate sits 13-fold (1.10 log units) below what was measured; measured number outside the range, above it.
By their numbers in this assay, from the lowest: compound 3; then compounds 1 and 2 (each within the scatter of the next); then compound 4.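

Amino in place of methoxy on this ring gives a 13-fold higher number from compound 1 to compound 4 (1.10 log units; beyond the scatter) in this assay, a large step towards weaker inhibition. Among the compounds shown here, the earlier steps changed only the other ring of the shared core, so this is the first sign that the group para to a large group can strongly affect the read-out. No measurement shown explains this loss.

As far as these compounds go, it remains open whether other groups here, such as ethoxy or dimethylamino, would stay near methoxy or fall towards amino. Whether amino has the same effect alongside chloro or hydroxy on the other ring is also unknown.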